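Swapping a chlorophenylethenyl arm for a pyrazolyl on a thiophene core

This account rests on a few compounds, and the source may have more. Where it says the series, first, only, none or still open, it means among the compounds named here.

Measured compounds:
- compound 1, `CC(C)(C)Cc1c(/C=C/c2ccc(Cl)cc2)sc(N)c1C(=O)c1ccc(Cl)cc1`: 11%
- compound 2, `CC(C)(C)Cc1csc(N)c1C(=O)c1cccc(C(F)(F)F)c1`: 1%
- compound 3, `Cc1ccc(C(=O)c2c(N)sc(-c3ccccc3)c2CC(C)(C)C)cc1`: 1%

All three compounds share a core carrying an amino group, a neopentyl group and an aryl carbonyl group, and all were tested in an assay on CHO cells for displacement of a labelled ligand from adenosine receptor A3 (Homo sapiens), read by scintillation counting, tested at 10 uM; a higher number here means more inhibition at the concentration tested (going by the name of the read-out), a lower number less inhibition. Compound 1 gives 11%, the highest of the three numbers, yet the gap to compound 2 at 1% and to compound 3 at 1% both fall within the usual scatter of such measurements, so the three numbers are level with one another and none can be called higher than the others. In short, every compound here shows little inhibition.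

Compound 4, `CC(C)(C)Cc1c(-c2cn[nH]c2)sc(N)c1C(=O)c1ccc(Cl)cc1`, has not yet been measured. It differs from compound 1 in one place: 1H-pyrazol-4-yl in place of 2-(4-chlorophenyl)ethenyl on an aromatic carbon. The group that leaves is large and carries a second chlorine-bearing ring; the group that enters is smaller and brings a hydrogen-bond donor and acceptor.

Among the compounds with values here, no pair among the measured compounds shows how such a change plays out, and all three numbers sit low. The step from compound 1 to compound 4 is therefore expected to stay within the scatter, a number 3 percentage points lower from compound 1 to compound 4 (within the scatter), with no clear direction. Compound 4 is expected to give about 8%, somewhere between 0% and 25%.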

Compound 4, a percentage reported as inhibition, at one concentration (the size of the read-out at that concentration, not a potency): 1%
Beside the measured number, compound 4's estimate is 7 percentage points above it; the measured number falls inside the stated range.
By their numbers in this assay, from the lowest: compounds 2, 3, 4 and 1 (each within the scatter of the next).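

Within the data shown here, this is the first pair in the set that differs only on the aromatic carbon next to the ring sulfur, so it gives the first direct reading of a change at this position. In this assay, putting 1H-pyrazol-4-yl in place of 2-(4-chlorophenyl)ethenyl gives a number 10 percentage points lower from compound 1 to compound 4 (within the scatter) and so separates the two compounds by no more than ordinary repeat variation, even though the larger all-carbon aromatic arm with its chlorine gives way to a smaller ring bearing a hydrogen-bond donor and acceptor. Nothing available explains why the number behaves this way, and with both compounds showing little inhibition, the pair cannot say whether the position matters for this receptor.

Going by these compounds, it remains open whether any group at this position can lift the inhibition clearly beyond the scatter, such as a carboxylic acid, a morpholine or a simple longer alkyl chain. It is also unknown whether the 1H-pyrazol-4-yl group would behave the same way if the neopentyl group or the (4-chlorophenyl)carbonyl group were replaced.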